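A few compounds are considered here, and "the series" means these few. Any claim that something is new, unique, unknown or untested is made for them only; others in the source may bear on it.

compound 1 `O=C1CS/C(=N/N=C/c2c[nH]c3ccccc23)N1c1cccc2ccccc12`: 25700 nM
compound 2 `S=C(N/N=C/c1c[nH]c2ccc(Br)cc12)Nc1cccc2ccccc12`: 1600 nM
compound 3 `Cc1ccc(NC(=S)N/N=C/c2c[nH]c3ccccc23)cc1`: 3880 nM

All three values come from a functional assay on OVCAR-3 cells (Homo sapiens) for inhibition, read by spectrophotometry and sulforhodamine B assay, with a stated time of 48 h; on this read-out lower numbers stand for stronger inhibition of growth and higher numbers for weaker inhibition of growth. Compound 2 has the lowest number of the three, and the gaps to compound 3 and compound 1 both lie beyond the scatter. Compound 4 `S=C(N/N=C/c1c[nH]c2ccccc12)Nc1cccc2ccccc12` is still unmeasured. Its structure differs from compound 2 in one place: hydrogen in place of bromo on an aromatic carbon, with hydrogen in place of bromo on an aromatic carbon. For the measured compounds named here, no measured pair shows this change alone. Compound 3 also carries no bromo and gives 3880 nM, a higher number, though it differs from compound 2 elsewhere too. A modest rise, slightly beyond the scatter, is therefore expected. The estimated change is a 2.2-fold higher number from compound 2 to compound 4 (0.34 log units; beyond the scatter). For compound 4 the estimated value is 3500 nM, with an expected range of 1400 nM to 9000 nM.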

Compound 4, concentration for 50% growth inhibition: 210 nM
Compound 4: middle estimate off by 17-fold (1.22 log units), on the high side, and the stated range ends above it.
By their numbers in this assay, from the lowest: compound 4; then compound 2; then compound 3; then compound 1.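

In this assay, putting hydrogen in place of bromo on this aromatic carbon gives a 7.6-fold lower number from compound 2 to compound 4 (0.88 log units; beyond the scatter) and this is the only pair shown that isolates the change. At this position, then, the compound without bromo inhibits growth more strongly, a direction that compound 3 could not reveal because it differs from compound 2 elsewhere too. Nothing measured here explains the step. On these data alone, whether a smaller halogen such as fluoro, or an amine or methoxy group, on the same carbon would match hydrogen remains open. So does whether the same change would act alike on the core of compound 1.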